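A few compounds are considered here, and "the series" means these few. Any claim that something is new, unique, unknown or untested is made for them only; others in the source may bear on it.

Compound 1 `Cc1nc(N)nc(N[C@@H]2C[C@H](CO)[C@@H](O)[C@H]2O)c1-c1nc2ccccc2s1` gives 1820 ng.h/mL in an ADME assay on the whole organism (plasma) for pharmacokinetics, with Rattus norvegicus as the target, with a stated time of 6 h, at a dose of 10 mg/kg by the oral route (a higher number here means more compound in the circulation at the dose given, a lower number less compound in the circulation), the highest of the three numbers measured. Compound 2 `Cc1nc(NCC(C)C)nc(N[C@@H]2C[C@H](CO)[C@@H](O)[C@H]2O)c1-c1nc2ccccc2s1` gives 1020 ng.h/mL, and compound 3 `Cc1nc(NCc2cccnc2)nc(N[C@@H]2C[C@H](CO)[C@@H](O)[C@H]2O)c1-c1nc2ccccc2s1` gives 9.57 ng.h/mL. The step of a 1.8-fold lower number from compound 1 to compound 2 (0.25 log units; within the scatter) lies within the scatter, whereas the steps of a 190-fold lower number from compound 1 to compound 3 (2.28 log units; beyond the scatter) and a 110-fold lower number from compound 2 to compound 3 (2.03 log units; beyond the scatter) are both large. Compound 4 `Cc1nc(NCc2ccncc2)nc(N[C@@H]2C[C@H](CO)[C@@H](O)[C@H]2O)c1-c1nc2ccccc2s1` differs from compound 1 by (pyridin-4-yl)methyl in place of hydrogen on a nitrogen on an aromatic ring. The step from compound 1 to compound 3 is the closest guide: there, too, a (pyridin-3-yl)methyl group entered on a nitrogen on an aromatic ring. Compound 4 is therefore expected to show a large drop in this assay, an estimated 120-fold lower number from compound 1 to compound 4 (2.08 log units; beyond the scatter). The expected value for compound 4 is 15 ng.h/mL, with a range from 3 ng.h/mL to 80 ng.h/mL.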

Compound 4, area under the concentration-time curve: 47.9 ng.h/mL
Compound 4: the middle estimate sits 3.2-fold (0.50 log units) below what was measured; measured number inside the range.
By their numbers in this assay, from the lowest: compound 3; then compound 4; then compounds 2 and 1 (each within the scatter of the next).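

The two pyridine isomers are not interchangeable at this nitrogen: pyridin-4-yl in place of pyridin-3-yl gives a 5.0-fold higher number from compound 3 to compound 4 (0.70 log units; beyond the scatter) in this assay. Even so, the pyridin-4-yl group does not restore the higher numbers, with a 38-fold lower number from compound 1 to compound 4 (1.58 log units; beyond the scatter) and a 21-fold lower number from compound 2 to compound 4 (1.33 log units; beyond the scatter). Nothing available here accounts for either difference. Going by these compounds, it remains open whether a benzyl group or a (pyridin-2-yl)methyl group on the same nitrogen would give a number nearer compound 1 or compound 3.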